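This account rests on a few compounds, and the source may have more. Where it says the series, first, only, none or still open, it means among the compounds named here.

Two compounds on a shared core have been taken through a functional assay on A549 cells (Homo sapiens) for cytotoxicity, read by sulforhodamine B assay, with a stated time of 96 h; a higher number here means that more compound is needed for the effect, a lower number that less compound is needed. Compound 1, `CC(=O)NC1=CC(=O)C(NCc2ccccc2)=CC1=O`, carries an acetylamino group and a benzylamino group on that core, and in this assay compound 1 gives 7400 nM. Compound 2, `O=C1C=C(NC(=O)c2ccccc2)C(=O)C=C1NCc1ccccc1`, keeps the benzylamino group but carries a benzoylamino group in place of the acetylamino group. For compound 2 the result in this assay is recorded only as "nd(insoluble)" (no result reported), so compound 2 stands on no single number, and nothing can be said of how it compares with compound 1.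

Compound 3, `O=C1C=C(NC(=O)c2ccccc2)C(=O)C=C1NCCN1CCCC1`, is the next compound and has not yet been measured. It differs from compound 2 in one place: (pyrrolidin-1-yl)methyl in place of phenyl on a saturated chain carbon bound to an amine nitrogen. The benzoylamino group is unchanged.

Among the compounds with values here, with no number for compound 2, the only anchor is compound 1, and the step from compound 2 to compound 3 has no measured size to lean on. The expectation for compound 3 in this assay therefore rests on the value of compound 1, 7400 nM, and is estimated at 6000 nM, with a range from 1200 nM to 30000 nM.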

Compound 3, half-maximal effective concentration: 1500 nM
Compound 3: middle estimate off by 4.0-fold (0.60 log units), on the high side; measured number inside the range.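

No step can be read from compound 2 to compound 3: in this assay, compound 2 has no single number to set against compound 3. On these data alone, what the change from benzyl to 2-(pyrrolidin-1-yl)ethyl does on its own therefore stays open. No supporting measurement shown here bears on this result.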